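A few compounds are considered here, and "the series" means these few. Any claim that something is new, unique, unknown or untested is made for them only; others in the source may bear on it.

Measured in a functional assay on DU-145 cells (Homo sapiens) for inhibition, read by trypan blue exclusion, with a stated time of 96 h; a higher number here means a weaker inhibitor of growth, a lower number a stronger inhibitor of growth:
- Compound 1 `COc1ccc(/C=C(/SCc2ccc(Cl)cc2)C(=O)c2ccc(Br)cc2)cc1O`: 1000 nM
- Compound 2 `CCOc1ccc(/C=C(/Sc2ccccc2Cl)C(=O)c2ccc(Cl)cc2)cc1OC`: 50000 nM
- Compound 3 `Cc1ccc(S(=O)(=O)/C(=C/c2ccc(F)cc2F)C(=O)c2ccc(Br)cc2)cc1`: > 100000 nM, which is a limit and not a number

Compound 2 holds the higher of the two true numbers, and its gap to compound 1 lies beyond the scatter. Compound 4 `CCOc1ccc(/C=C(\C(=O)c2ccc(Cl)cc2)S(=O)(=O)Cc2ccccc2Cl)cc1OC` carries (2-chlorobenzyl)sulfonyl in place of (2-chlorophenyl)sulfanyl on a double-bonded chain carbon bound to a carbonyl carbon and a double-bonded chain carbon. Going by the values given here, no measured pair differs in one place, so the expectation is loose. Like compound 4, compound 1 carries a benzyl group, and compound 1 gives 1000 nM, which points toward a lower number. Compound 3, the other sulfonyl compound, points the opposite way. The expected change is modest, an estimated 5.0-fold lower number from compound 2 to compound 4 (0.70 log units; beyond the scatter). For compound 4 the estimated value is 10000 nM, expected to fall between 1500 nM and 100000 nM.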

Compound 4, concentration for 50% growth inhibition: 10000 nM
Compound 4: the middle estimate sits on the measured number at the digits printed, within the range that was stated.
By their numbers in this assay, from the lowest: compound 1; then compound 4; then compound 2. At a limit, above all of these: compound 3.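

At the double-bonded chain carbon bound to a carbonyl carbon and a double-bonded chain carbon, this assay now gives a directly readable change: a 5.0-fold lower number from compound 2 to compound 4 (0.70 log units; beyond the scatter), with (2-chlorobenzyl)sulfonyl in place of (2-chlorophenyl)sulfanyl. Compound 4 thus shows that a sulfonyl group at this place can go with a true number rather than a limit. No measurement shown gives a cause for this step. The step combines the sulfonyl group with the benzyl carbon, leaving their separate contributions open. Neither (2-chlorobenzyl)sulfanyl nor (2-chlorophenyl)sulfonyl is among the compounds shown on this core.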